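Benzyl halogen swaps: working notes toward compound 3

A few compounds are considered here, and "the series" means these few. Any claim that something is new, unique, unknown or untested is made for them only; others in the source may bear on it.

Compound 1 `CCCSc1nc(N/N=C(\C)c2ccccc2O)c2nnn(Cc3ccccc3Cl)c2n1`: in a functional assay on MCF7 cells (Homo sapiens) for antiproliferative activity, read by MTT assay, with a stated time of 72 h (on this read-out higher numbers stand for weaker inhibition and lower numbers for stronger inhibition), compound 1 gives > 64000 nM, a limit of the assay.
Compound 2 `CCCSc1nc(N/N=C(\C)c2ccccc2O)c2nnn(Cc3ccc(F)cc3)c2n1`: in this assay compound 2 gives > 64000 nM, likewise a limit.

Compound 2 stands at the assay limit; the limit of > 64000 nM in this assay, at which 2 of the 2 values shown sit, places both measured values there, so the step that the two limits leave unreadable from compound 1 to compound 2 cannot be read. Compound 3 `CCCSc1nc(N/N=C(\C)c2ccccc2O)c2nnn(Cc3cccc(Cl)c3)c2n1` differs from compound 2 by 3-chlorophenyl in place of 4-fluorophenyl on a saturated chain carbon bound to an aromatic nitrogen. Going by the values given here, no measured step bears readably on this change, and no direction can be drawn from the two limits. The step that the limit leaves unreadable from compound 2 to compound 3 is expected to be none beyond the scatter. Compound 3 is estimated at 100000 nM, range 30000 nM to 400000 nM, most likely reported again only as a limit.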

Compound 3, half-maximal inhibitory concentration: 39900 nM
Estimate against measurement, compound 3: 2.5-fold (0.40 log units) above; the measured number falls inside the stated range.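

In this assay compound 3 alone of the three gives a number, 39900 nM, so a change on the saturated chain carbon bound to an aromatic nitrogen can bring a value inside the measured range. The readable steps are an at least 1.6-fold lower number from compound 2 to compound 3 (0.20 log units; that floor lies within the scatter) and an at least 1.6-fold lower number from compound 1 to compound 3 (0.20 log units; that floor lies within the scatter), the latter keeping chlorine on the ring; the step from compound 1 to compound 2 cannot be read. Both readable steps remain floors, not sizes: the limit of > 64000 nM in this assay, at which 2 of the 3 values shown sit.

From the compounds shown here alone, whether the readable number belongs to 3-chlorophenyl alone stays open. Also open, going by these compounds, is how 3-fluorophenyl, 3-methoxyphenyl or 3-aminophenyl would read at this place.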